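The compounds below may be only part of what the source reports. "The series", "measured", "known", "first", "only" and "open" are said of these compounds alone.

Three compounds share one core, with a different group on the aromatic carbon of the outer ring. Compound 1 `CCc1ccc(C(=O)OCc2cn(-c3ccnc4cc(Cl)ccc34)nn2)cc1` carries ethyl, compound 2 `CC(C)(C)c1ccc(C(=O)OCc2cn(-c3ccnc4cc(Cl)ccc34)nn2)cc1` tert-butyl, and compound 3 `O=C(OCc1cn(-c2ccnc3cc(Cl)ccc23)nn1)c1ccc(C(F)(F)F)cc1` trifluoromethyl. In an ADME assay on HepG2 cells (Homo sapiens) for cytotoxicity, read by MTT assay, with a stated time of 24 h (a lower number here means that less compound is tolerated, a higher number that more compound is tolerated), compound 1 gives only a limit of the assay, > 2550000 nM. Compound 2 also gives only a limit, > 2380000 nM. For the measured compounds named here, compound 3 gives 1070000 nM, the only actual number of the three. The steps of an at least 2.3-fold lower number from compound 1 to compound 3 (0.37 log units; beyond the scatter) and an at least 2.2-fold lower number from compound 2 to compound 3 (0.34 log units; beyond the scatter) both lower the number. Compound 4 `COc1ccc(C(=O)OCc2cn(-c3ccnc4cc(Cl)ccc34)nn2)cc1` differs from compound 3 by methoxy in place of trifluoromethyl on an aromatic carbon. Going by the values given here, no measured step involves methoxy, so the expectation rests on trifluoromethyl leaving; the number is expected to rise by a 2.1-fold higher number from compound 3 to compound 4 (0.31 log units; beyond the scatter), giving an estimated 2200000 nM for compound 4, between 900000 nM and 5000000 nM.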

Compound 4, half-maximal cytotoxic concentration: 303000 nM
Beside the measured number, compound 4's estimate is 7.3-fold (0.86 log units) above it, outside the stated range (below it).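

In this assay, methoxy at this place on the outer ring gives the lowest number of the four compounds, with a 3.5-fold lower number from compound 3 to compound 4 (0.55 log units; beyond the scatter) and an at least 7.8-fold lower number from compound 2 to compound 4 (0.89 log units; beyond the scatter) and an at least 8.4-fold lower number from compound 1 to compound 4 (0.92 log units; beyond the scatter). The first of these steps is the only one with actual numbers at both ends, and methoxy is the only group shown that carries a hydrogen-bond acceptor. Nothing measured here accounts for the drop. From the compounds shown here alone, whether an amine, a carboxylic acid or a longer chain at this place would lower the number further remains open.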